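Sulfonamide aryl substituent: phenoxy in place of trifluoromethyl

This account rests on a few compounds, and the source may have more. Where it says the series, first, only, none or still open, it means among the compounds named here.

Compound 2 `O=C(/C=C/c1cccnc1)NCCCCCCc1cccc(S(=O)(=O)Nc2ccc(C(F)(F)F)cc2)c1` carries a trifluoromethyl on the aryl ring of the sulfonamide. Among the compounds with values here, in an assay on isolated protein for inhibition of Nicotinamide phosphoribosyltransferase (Homo sapiens), read by WST assay, with stated times of 60 min, 5 min and 30 min, in the presence of a further agent that is not named here (a lower number here means a stronger inhibitor, a higher number a weaker inhibitor), compound 2 gives 24.5 nM, the highest number of the two measured so far. Its nearest neighbour is compound 1 `O=C(/C=C/c1cccnc1)NCCCCCCc1cccc(S(=O)(=O)Nc2ccccc2)c1`, the unsubstituted parent, which in this assay gives 10.5 nM. Within the data shown here, the one step measured, a 2.3-fold higher number from compound 1 to compound 2 (0.37 log units; beyond the scatter), is a modest loss of potency on introducing the trifluoromethyl.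

Compound 3 `O=C(/C=C/c1cccnc1)NCCCCCCc1cccc(S(=O)(=O)Nc2ccc(Oc3ccccc3)cc2)c1` is the next member: phenoxy in place of trifluoromethyl on an aromatic carbon. Among the measured compounds shown here, no measured step bears directly on a phenoxy at this place; the only reference is the trifluoromethyl step just noted, which was small and beyond the scatter. A second substituent at the same position is therefore expected to stay close to compound 2 in this assay, with a slight further weakening the more likely direction than a gain, and a wide range to cover the unknown. The expected step is a 1.3-fold higher number from compound 2 to compound 3 (0.12 log units; within the scatter). For compound 3 the estimate in this assay is 32 nM, within a range from 10 nM to 100 nM.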

Compound 3, half-maximal inhibitory concentration: 13.1 nM
Estimate against measurement, compound 3: 2.4-fold (0.39 log units) above; low and high end bracket the measured number.
By their numbers in this assay, from the lowest: compounds 1, 3 and 2 (each within the scatter of the next, the first and the last beyond it).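

In this assay, the phenoxy group, which brings a further six-membered aromatic ring to this place, stands within the scatter of both neighbours (a 1.9-fold lower number from compound 2 to compound 3 (0.27 log units; within the scatter); a 1.2-fold higher number from compound 1 to compound 3 (0.10 log units; within the scatter)). Within the data shown here, the position therefore carries a group of 7 heavy atoms with no step from the unsubstituted parent beyond the scatter, which the trifluoromethyl result alone could not show. Compound 3 sits within the scatter of compound 1 and of compound 2, although those two lie beyond the scatter of each other (a 2.3-fold higher number from compound 1 to compound 2 (0.37 log units; beyond the scatter)), so these numbers give no order for phenoxy against hydrogen or against trifluoromethyl, and no measurement here speaks to why the numbers fall as they do.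

On these data alone, two substituents at one place cannot show whether any group there moves the number far beyond the scatter in either direction, and an amine, a carboxylic acid or a methoxy at the same carbon remains open. Also open, as far as these compounds go, is whether a substituent on the outer ring of the phenoxy, such as a chlorine or a nitrile, would leave the number within the scatter of compound 3.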